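This account rests on a few compounds, and the source may have more. Where it says the series, first, only, none or still open, it means among the compounds named here.

In a functional assay on OVCAR-3 cells (Homo sapiens) for antiproliferative activity, read by MTT assay, with a stated time of 24 h (a lower number here means a stronger inhibitor, a higher number a weaker inhibitor), compound 3 `Cc1cccc(NNC(=O)c2cccc(NS(=O)(=O)c3cnc(O)nc3O)c2)c1` gives > 20000 nM as a limit, not a number. Compound 1 `Cc1cccc(NNC(=O)c2ccc(NS(=O)(=O)c3cnc(O)nc3O)cc2)c1` likewise gives only a limit (> 20000 nM). Compound 2 `O=C(NNc1ccccc1Cl)c1ccc(NS(=O)(=O)c2cnc(O)nc2O)cc1` gives a true number (7230 nM). Compound 4 `O=C(NNc1ccc(F)cc1)c1cccc(NS(=O)(=O)c2cnc(O)nc2O)c1` carries 4-fluorophenyl in place of 3-methylphenyl on an amine nitrogen is the whole difference. Among the compounds with values here, the one measured step that bears on this swaps 3-methylphenyl for 2-chlorophenyl on the same nitrogen, and it is an at least 2.7-fold lower number from compound 1 to compound 2 (0.44 log units; beyond the scatter) on a differently arranged core. A modest move toward a lower number is therefore expected, estimated as an at least 1.4-fold lower number from compound 3 to compound 4 (0.15 log units; that floor lies within the scatter) in this assay for now. With the limit of > 20000 nM in this assay, at which 2 of the 3 values shown sit, compound 4 could well report only a limit too. The estimate for compound 4 is 14000 nM (expected range 6000 nM to 32000 nM).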

Compound 4, half-maximal inhibitory concentration: > 20000 nM
Compound 4: only a limit was reported (the forecaster's own chance of this, stated with the estimate: 50%); at least 1.4-fold (0.15 log units) between middle value and limit.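

Compound 3 and compound 4 both give only a limit in this assay, so the step between them cannot be read: the limit of > 20000 nM in this assay, at which 3 of the 4 values shown sit.

The compounds shown leave open what true number lies behind either limit, and whether 4-fluorophenyl in place of 3-methylphenyl on an amine nitrogen changes anything here.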